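Aryl in place of pentynyl in a nucleoside series

This account rests on a few compounds, and the source may have more. Where it says the series, first, only, none or still open, it means among the compounds named here.

Measured compounds in a functional assay on CAPAN-1 cells (Homo sapiens) for antiproliferative activity, with a stated time of 72 h; on this read-out lower numbers stand for stronger inhibition and higher numbers for weaker inhibition:
- compound 1, `CCCC#Cc1cc([C@@H]2O[C@H](CO)[C@@H](O)[C@H]2O)n2ncnc(N)c12`: 20 nM
- compound 2, `Nc1ncnn2c([C@@H]3O[C@H](CO)[C@@H](O)[C@H]3O)cc(-c3ccc(Cl)cc3)c12`: 56700 nM
- compound 3, `Nc1ncnn2c([C@@H]3O[C@H](CO)[C@@H](O)[C@H]3O)cc(-c3ccc(F)cc3F)c12`: 50900 nM

Compound 1 stands lowest of the three numbers in this assay, and both others lie far from it: compound 2 at 56700 nM and compound 3 at 50900 nM are beyond the scatter from compound 1 by a wide margin.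

Compound 4, `Cc1ccccc1-c1cc([C@@H]2O[C@H](CO)[C@@H](O)[C@H]2O)n2ncnc(N)c12`, has not yet been measured. It differs from compound 1 in one place: 2-methylphenyl in place of pent-1-yn-1-yl on an aromatic carbon. This is the same kind of change as in the two measured steps from compound 1, where one six-membered aromatic ring of carbon only enters in place of pent-1-yn-1-yl. Those steps were a 2800-fold higher number from compound 1 to compound 2 (3.45 log units; beyond the scatter) and a 2500-fold higher number from compound 1 to compound 3 (3.41 log units; beyond the scatter), both large and both in the same direction. Between the two aryl compounds the step was a 1.1-fold lower number from compound 2 to compound 3 (0.05 log units; within the scatter), within the scatter, so the choice of substituent on the ring made no visible difference in the compounds so far.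

On this basis a large rise in this assay is expected for compound 4, of about a 2000-fold higher number from compound 1 to compound 4 (3.30 log units; beyond the scatter). The estimate for compound 4 is 40000 nM, with a range from 10000 nM to 150000 nM.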

Compound 4, half-maximal inhibitory concentration: 97500 nM
Estimate against measurement, compound 4: 2.4-fold (0.39 log units) below, within the range that was stated.
By their numbers in this assay, from the lowest: compound 1; then compounds 3, 2 and 4 (each within the scatter of the next).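

With a third aryl group the large loss in this assay recurs, a 4900-fold higher number from compound 1 to compound 4 (3.69 log units; beyond the scatter), so it is not confined to the halogen-bearing rings of compounds 2 and 3 and also appears with the methyl-bearing ring of 2-methylphenyl. Among the aryl compounds, the steps are a 1.9-fold higher number from compound 3 to compound 4 (0.28 log units; within the scatter) and a 1.7-fold higher number from compound 2 to compound 4 (0.24 log units; within the scatter), both within the scatter, so methyl in place of halogen on the ring gives no visible change and these three compounds cannot be told apart in this assay. No measurement at hand bears on the gap between pent-1-yn-1-yl and the aryl groups.

Still open, going by these compounds, is whether the low number of compound 1 rests on the triple bond or on the chain as such: a saturated pentyl chain, a shorter prop-1-yn-1-yl or a longer hex-1-yn-1-yl on the same aromatic carbon would separate these possibilities. Also open, on these data alone, is whether every ring at this place behaves like the three aryl groups, which a pyridyl ring, or a phenyl ring carrying an amine or a carboxylic acid, would test.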